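A few compounds are considered here, and "the series" means these few. Any claim that something is new, unique, unknown or untested is made for them only; others in the source may bear on it.

Measured so far:
compound 1 `COc1cc2c(cc1OC)C(CC(=O)Nc1ccc(Br)cc1)CC2`: 66.7%
compound 2 `COc1ccccc1NC(=O)CC1CCc2cc(OC)c(OC)cc21`: 30%

Going by the values given here, in a functional assay on the whole organism (strain Wistar) for inhibition, with Rattus norvegicus as the target, read by paw edema, with a stated time of 24 h, at a dose of 100 mg/kg (a lower number here means less inhibition, a higher number more inhibition at the dose given (going by the name of the read-out)), compound 2 gives 30%, the lower of the two numbers; compound 1 gives 66.7%, and the only measured step is a number 36.7 percentage points lower from compound 1 to compound 2 (beyond the scatter). Compound 3 `COc1cc2c(cc1OC)C(CC(=O)Nc1cccnc1)CC2` differs from compound 2 by pyridin-3-yl in place of 2-methoxyphenyl on an amide-type nitrogen. Among the compounds with values here, the one step known, a number 36.7 percentage points lower from compound 1 to compound 2 (beyond the scatter), also swaps the group on this amide-type nitrogen and shows that such swaps can move the read-out by a large amount, but no pyridin-3-yl example exists. The step expected is a number 15 percentage points higher from compound 2 to compound 3 (beyond the scatter), upward but uncertain. Compound 3 is estimated at 45%, in the range 20% to 70%.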

Compound 3, a percentage reported as inhibition, in the whole organism at one dose (the size of the read-out at that dose, not a potency): 36.7%
Beside the measured number, compound 3's estimate is 8.3 percentage points above it; the range from low to high includes it.
By their numbers in this assay, from the lowest: compounds 2 and 3 (each within the scatter of the next); then compound 1.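

In this assay, pyridin-3-yl in place of 2-methoxyphenyl on the amide-type nitrogen gives a number 6.7 percentage points higher from compound 2 to compound 3 (within the scatter), so two quite different aromatic groups here cannot be told apart. Set against 4-bromophenyl, pyridin-3-yl gives a number 30 percentage points lower from compound 1 to compound 3 (beyond the scatter), and compound 1 now stands apart from both compound 2 and compound 3. Nothing available accounts for either step. Open, as far as these compounds go, is whether unsubstituted phenyl or 4-chlorophenyl on this nitrogen would fall with compound 1 or with the other two. Also open, from the compounds shown here alone, is how a benzyl group or a saturated cyclohexyl ring would read out here.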